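Swapping a Pyrrolidine for Chlorine on an Aryl Ring

This account rests on a few compounds, and the source may have more. Where it says the series, first, only, none or still open, it means among the compounds named here.

Of the compounds shown here, two sharing one core have been tested in a functional assay on HepG2 cells (Homo sapiens) for antiproliferative activity, read by MTT assay, with a stated time of 24 h; on this read-out higher numbers stand for weaker inhibition and lower numbers for stronger inhibition. Compound 1 `COc1ccc(C(=O)/C=C/c2ccc3ccccc3c2)c2c1C=CC(C)(C)O2` carries a naphthalene on the far end of its enone linker, and in this assay compound 1 gives 210 nM. Compound 2 `COc1ccc(C(=O)/C=C/c2ccc(N3CCCC3)cc2)c2c1C=CC(C)(C)O2` instead carries a benzene ring bearing a pyrrolidin-1-yl group, and in this assay compound 2 gives 4740 nM. Among the two numbers known, compound 2 stands highest, that is, it is the weaker inhibitor of the pair, and its distance from compound 1 lies beyond the scatter of repeated measurements.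

Compound 3 `COc1ccc(C(=O)/C=C/c2ccc(Cl)cc2)c2c1C=CC(C)(C)O2` keeps everything in compound 2 except one group: chloro in place of pyrrolidin-1-yl on an aromatic carbon. Within the data shown here, no measured pair shows exactly this exchange, so the expectation rests on the weak showing of compound 2 alone. Because compound 2 gives 4740 nM, there is room for movement downward, toward stronger inhibition. The step from compound 2 to compound 3 is expected to be moderate and downward, a 3.2-fold lower number from compound 2 to compound 3 (0.50 log units; beyond the scatter), likely beyond the scatter. In this assay compound 3 is therefore estimated at 1500 nM, within a range from 400 nM to 6000 nM.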

Compound 3, half-maximal inhibitory concentration: > 10000 nM
Compound 3: only a limit was reported; the forecaster's own chance of this, stated with the estimate: 5%; middle value at least 6.6-fold (0.82 log units) away from the limit.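

Compound 3 is reported only as a limit, not as a number: the limit of > 10000 nM in this assay, at which 1 of the 3 values shown sits.

In this assay, exchanging pyrrolidin-1-yl for chloro on this aromatic carbon, para to a large group, gives an at least 2.1-fold higher number from compound 2 to compound 3 (0.32 log units; beyond the scatter), so the position is not indifferent to what it carries, and this change moves the compound toward weaker inhibition. Among these compounds, compound 2 could previously be judged only by its own weak showing, with no pair to indicate what its pyrrolidin-1-yl group was worth, whereas this pair shows that the group retains more activity than chloro does. A modest level of inhibition at this position can therefore still be lost, and a small halogen is not an improvement on the five-atom ring here.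

The compounds shown leave open which feature of pyrrolidin-1-yl matters: its nitrogen, its ring or simply its number of atoms. A dimethylamino group, a morpholine ring or a cyclopentyl ring on the same carbon, compared with a plain hydrogen there, would begin to separate these possibilities.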